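Tertiary amide in place of the thienylmethyl amide

A few compounds are considered here, and "the series" means these few. Any claim that something is new, unique, unknown or untested is made for them only; others in the source may bear on it.

Two compounds of the shared core carry measured numbers in a functional assay on BHK cells for positive allosteric modulation of metabotropic glutamate receptor 5 (Homo sapiens), read by FLIPR and calcium flux; on this read-out lower numbers stand for an effect already at smaller amounts and higher numbers for an effect only at larger amounts of compound. Compound 1 `CC(C)CCNC(=O)c1ccc(C#Cc2ccccc2)nc1` gives 510 nM. Going by the values given here, compound 2 `O=C(NCc1ccsc1)c1ccc(C#Cc2ccccc2)nc1` gives 140 nM, the lowest number of the pair; its only neighbour is compound 1, and that step is a 3.6-fold lower number from compound 1 to compound 2 (0.56 log units; beyond the scatter).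

Compound 3 `CC1CCN(C(=O)c2ccc(C#Cc3ccccc3)nc2)CC1` differs from compound 2 in one place: 4-methylpiperidin-1-yl in place of ((thiophen-3-yl)methyl)amino on a carbonyl carbon. The secondary amide of compound 2 thus becomes a tertiary amide with no hydrogen-bond donor left on that nitrogen, and the aromatic five-membered ring is replaced by a saturated six-membered ring.

Among the compounds with values here, only the step from compound 1 to compound 2 bears on this, and only loosely: it shows that the amide substituent matters, with a saturated branched chain on the nitrogen giving the higher number. Within the data shown here, no measured step removes the amide hydrogen. Given that compound 1 gives 510 nM with a saturated group, and that compound 3 additionally loses the donor, the expected direction for compound 3 is towards a higher number, with an estimated step of an 8.6-fold higher number from compound 2 to compound 3 (0.93 log units; beyond the scatter). For compound 3 the expected value is 1200 nM, within a range from 300 nM to 5000 nM.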

Compound 3, half-maximal effective concentration: 130 nM
Beside the measured number, compound 3's estimate is 9.2-fold (0.97 log units) above it; measured number below the stated range.
By their numbers in this assay, from the lowest: compounds 3 and 2 (each within the scatter of the next); then compound 1.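

In this assay, 4-methylpiperidin-1-yl in place of ((thiophen-3-yl)methyl)amino on the carbonyl carbon gives a 1.1-fold lower number from compound 2 to compound 3 (0.03 log units; within the scatter), so among the compounds shown, neither the amide hydrogen nor the five-membered aromatic ring is needed to stay at the level of compound 2. The same group in place of isopentylamino gives a 3.9-fold lower number from compound 1 to compound 3 (0.59 log units; beyond the scatter), so a saturated group on this carbonyl carbon does not by itself go with the higher number of compound 1. Nothing at hand accounts for either step.

As far as these compounds go, the step from compound 2 to compound 3 removes the amide hydrogen and exchanges the ring at once, so the contribution of each stays open; a tertiary amide carrying methyl and (thiophen-3-yl)methyl would keep the ring while losing that hydrogen. Also open, from the compounds shown here alone, is what the methyl group of 4-methylpiperidin-1-yl contributes, which plain piperidin-1-yl would address, and whether a hetero atom added to the saturated ring, as in morpholin-4-yl, would leave the number within the scatter of compound 3.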